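The source may hold more compounds than are shown below. What is called first, only, known or untested is meant among the compounds shown, and "the series" means these compounds.

Values in a functional assay on the whole organism with Mus musculus as the target (a higher number here means that more compound is needed for the effect, a lower number that less compound is needed), so far

- compound 1 `Cc1c(C)c2c(c(C)c1N)CC(C)(CSCCO)O2` gives > 50 mg/kg (a limit, not a number)
- compound 2 `COCC1(C)Cc2c(C)c(N)c(C)c(C)c2O1` gives 20.1 mg/kg

Among the compounds with values here, compound 2 carries the only actual number, at 20.1 mg/kg in this assay. Compound 1 is known only by its limit.

Next is compound 3 `Cc1c(C)c2c(c(C)c1N)CC(C)(CN1CCCCC1)O2`, with piperidin-1-yl in place of methoxy on a saturated chain carbon bound to a saturated ring carbon. Within the data shown here, one measured step bears on this place: an at least 2.4-fold lower number from compound 1 to compound 2 (0.39 log units; beyond the scatter). It shows that the group here can move the number in this assay, but it is a single step with a limit at one end, so the forecast is loose. A modest move to a higher number is expected, and the estimate is a 1.4-fold higher number from compound 2 to compound 3 (0.14 log units; within the scatter). For compound 3 the expected value is 28 mg/kg, with an estimated range from 9 mg/kg to 75 mg/kg.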

Compound 3, dose for 50% inhibition: 11.7 mg/kg
Compound 3: the middle estimate sits 2.4-fold (0.38 log units) above what was measured; measured number inside the range.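

In this assay, the step from methoxy to piperidin-1-yl on this saturated chain carbon stays inside the scatter: a 1.7-fold lower number from compound 2 to compound 3 (0.24 log units; within the scatter). This place therefore takes a group with one six-membered non-aromatic ring as well as the smaller methoxy, with no separation between the two values, and the replacement of (2-hydroxyethyl)sulfanyl now reads an at least 4.2-fold lower number from compound 1 to compound 3 (0.63 log units; beyond the scatter), so both replacements of that group lie beyond the scatter. The size of that step has one open end, as compound 1 is known only by a limit: the limit of > 50 mg/kg in this assay, at which 1 of the 3 values shown sits.

The compounds shown leave open whether an open-chain amine such as dimethylamino, a carboxylic acid or a longer chain at this place would give a number clearly apart from those of compound 2 and compound 3. They also leave open whether any group here goes beyond the scatter in the direction of a lower number than these two.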